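A few compounds are considered here, and "the series" means these few. Any claim that something is new, unique, unknown or untested is made for them only; others in the source may bear on it.

Three measured compounds share a linker that joins an acidic aromatic half to a hydroxylated, acylated aromatic half, and differ in the acyl chain and in the substituents on the acidic ring. Compound 1 `CCCC(=O)c1ccc(OCCCCOc2cc(C(=O)O)ccc2OC)c(C)c1O` gives 82.8% in an assay on HEK293 cells for positive allosteric modulation of metabotropic glutamate receptor 2 (Rattus norvegicus), read by thallium flux, with a stated time of 2.5 min; on this read-out higher numbers stand for larger maximal responses and lower numbers for smaller maximal responses. Compound 2 `CCC(=O)c1ccc(OCCCCOc2ccc(C(=O)O)cc2C)c(C)c1O` gives 86.6% in this assay. Compound 3 `COc1ccc(C(=O)O)cc1OCCCCOc1ccc(C(=O)CC(C)C)c(O)c1C` gives 89.7% in this assay. The difference between the cores of compound 2 and compound 3 is not broken down here. Compound 3 and compound 1 differ in one place, (hydrogen in place of methyl on a saturated chain carbon bound to two saturated chain carbons), and the step that this change made is a number 6.9 percentage points lower from compound 3 to compound 1 (within the scatter).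

Compound 4 `CC(=O)c1ccc(OCCCCOc2ccc(C(=O)O)cc2C)c(C)c1O` has not yet been measured in this assay. It differs from compound 2 by hydrogen in place of methyl on a saturated chain carbon bound to a carbonyl carbon. Going by the values given here, this is the same kind of change as the one from compound 3 to compound 1, but not the same: there the carbon that loses the methyl is bound to two saturated chain carbons, here it is bound to a carbonyl carbon. The change occurs twice among the compounds shown, once measured and once not.

For the step from compound 2 to compound 4 he expects a number 1.6 percentage points lower from compound 2 to compound 4 (within the scatter) in this assay, because the earlier step of a number 6.9 percentage points lower from compound 3 to compound 1 (within the scatter) stayed within the scatter, and all three measured values lie within the scatter of one another. He therefore estimates that compound 4 will give 85%, with a range from 72% to 96%.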

Compound 4, largest response reached (reported as percent of maximum), in percent of the reference or control that the assay uses: 83.1%
Beside the measured number, compound 4's estimate is 1.9 percentage points above it; low and high end bracket the measured number.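

In this assay, the step from propanoyl to acetyl reads a number 3.5 percentage points lower from compound 2 to compound 4 (within the scatter), so removing this methyl from the acyl chain leaves the maximal response indistinguishable from that of compound 2. Set beside the earlier removal of a methyl from an acyl chain, the new step shows no difference between the two cores: the same change on two cores in this assay, a number 6.9 percentage points lower (within the scatter) from compound 3 to compound 1 and a number 3.5 percentage points lower (within the scatter) from compound 2 to compound 4, 3.4 percentage points apart, within the scatter of two such steps. This supports only a modest statement, namely that on these two cores the change gave no step beyond the scatter; it does not fix a size for the change that could be carried to a further core, and the comparison is not a clean one, since the carbon that loses the methyl is bound to two saturated chain carbons in one case and to a carbonyl carbon in the other.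

The compounds shown leave open whether any acyl group would give a step beyond the scatter, for instance one with a much longer chain, a terminal amine or a phenyl ring. They also leave open how the response would stand with an amide or a tetrazole in place of the carboxylic acid, or with a longer chain as the linker.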